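This account rests on a few compounds, and the source may have more. Where it says the series, first, only, none or still open, it means among the compounds named here.

Compound 2 `CC(CN1N=C(c2ccccc2)CCC1=O)C(=N)S` and compound 3 `N=C(S)CCN1N=C(c2ccccc2)CCC1=O` share a core that differs only in the side chain, as counted in hydrogen in place of methyl on a saturated chain carbon bound to a carbon with a double bond to nitrogen and a saturated chain carbon. In a functional assay on the whole organism (stomach) for inhibition, with Rattus norvegicus as the target, at a dose of 100 mg/kg by the intraduodenal route (a higher number here means more inhibition at the dose given (going by the name of the read-out), a lower number less inhibition), compound 2 gives 28.2%, and compound 3 gives 38.2%; the step of a number 10 percentage points higher from compound 2 to compound 3 (within the scatter) lies within the scatter, so the two cannot be ordered. Compound 1 `CC1=NN(CC(C)C(=N)S)C(=O)CC1` arises from compound 2 by the change (methyl in place of phenyl on a carbon with a double bond to nitrogen), and in this assay compound 1 gives 15.6%, a drop described by a number 12.6 percentage points lower from compound 2 to compound 1 (beyond the scatter). Compound 4 `CC1=NN(CCC(=N)S)C(=O)CC1` stands to compound 3 as compound 1 stands to compound 2, through the change (methyl in place of phenyl on a carbon with a double bond to nitrogen); this is the same kind of change, though the place now lies two ring bonds from the ring atom that bears a group of 5 heavy atoms rather than 6. For compound 4 in this assay a step of a number 12.2 percentage points lower from compound 3 to compound 4 (beyond the scatter) is expected, resting on the earlier step of a number 12.6 percentage points lower from compound 2 to compound 1 (beyond the scatter) seen for compound 1. Accordingly, compound 4 is estimated at 26%, with a likely range from 14% to 38%.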

Compound 4, a percentage reported as inhibition, in the whole organism at one dose (the size of the read-out at that dose, not a potency): 34.8%
Beside the measured number, compound 4's estimate is 8.8 percentage points below it; the range from low to high includes it.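

In this assay, methyl in place of phenyl on the core without the chain methyl gives a number 3.4 percentage points lower from compound 3 to compound 4 (within the scatter), and set beside the same change on the core that keeps the chain methyl, the two steps do not differ by more than the scatter allows: the same change on two cores in this assay, a number 12.6 percentage points lower (beyond the scatter) from compound 2 to compound 1 and a number 3.4 percentage points lower (within the scatter) from compound 3 to compound 4, 9.2 percentage points apart, within the scatter of two such steps

Hydrogen in place of methyl on the saturated chain carbon gives a number 19.2 percentage points higher from compound 1 to compound 4 (beyond the scatter), and this change also agrees across the phenyl and methyl cores within the scatter: the same change on two cores in this assay, a number 10 percentage points higher (within the scatter) from compound 2 to compound 3 and a number 19.2 percentage points higher (beyond the scatter) from compound 1 to compound 4, 9.2 percentage points apart, within the scatter of two such steps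

The two pairs are thus compatible with each change carrying from one core to the other, but in each pair one step lies within the scatter and the other beyond it, so they do not fix the size of either change or exclude a smaller real difference between the cores.

The compounds shown leave open whether an amine or a carboxylic acid on the carbon with a double bond to nitrogen would fit the same picture, and whether a longer chain would do so in place of the present side chain. With a reading at one dose only, they also say nothing about potency.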